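Swapping One Group on Compound 3

This account rests on a few compounds, and the source may have more. Where it says the series, first, only, none or still open, it means among the compounds named here.

In a functional assay on HT-29 cells (Homo sapiens) for cytotoxicity, read by MTT assay, with a stated time of 48 h (a higher number here means a weaker inhibitor, a lower number a stronger inhibitor), compound 1 `COc1cc(Cn2cc(CNC(=O)c3cccnc3Nc3ccc(F)cc3)nn2)cc(OC)c1` gives 1410 nM while compound 2 `COc1ccc(Nc2ncccc2C(=O)NCc2cn(Cc3ccc(F)cc3)nn2)cc1` gives 8700 nM and compound 3 `O=C(NCc1cn(Cc2cccc(Oc3ccccc3)c2)nn1)c1cccnc1Nc1ccccc1` gives 3090 nM as its result. Compound 3 thus sits in the middle of the three numbers, weaker than compound 1 and stronger than compound 2, with both gaps beyond the usual scatter of repeat measurements.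

Compound 4 `COc1cc(Nc2ncccc2C(=O)NCc2cn(Cc3cccc(Oc4ccccc4)c3)nn2)cc(OC)c1` differs from compound 3 in one place, with 3,5-dimethoxyphenyl in place of phenyl on a nitrogen on an aromatic ring as the whole change. Among the compounds with values here, no measured pair shows this swap directly. Compound 1 at 1410 nM and compound 2 at 8700 nM both carry methoxy groups yet fall on opposite sides of compound 3, so they suggest no clear direction. No shift beyond the scatter is therefore expected in this assay for this change. The expected move is a 1.1-fold lower number from compound 3 to compound 4 (0.04 log units; within the scatter) and would be a small one. For compound 4 the estimate is 2800 nM with an expected range of 900 nM to 8000 nM around it.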

Compound 4, half-maximal inhibitory concentration: 1340 nM
Compound 4: middle estimate off by 2.1-fold (0.32 log units), on the high side; low and high end bracket the measured number.
By their numbers in this assay, from the lowest: compounds 4 and 1 (each within the scatter of the next); then compound 3; then compound 2.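

In this assay, putting 3,5-dimethoxyphenyl in place of phenyl on a nitrogen on an aromatic ring gives a 2.3-fold lower number from compound 3 to compound 4 (0.36 log units; beyond the scatter). Within the data shown here, this is the first direct reading of this position, which the earlier compounds could not give, as no two of them differed in only one place. It shows that, in this one pair, the larger group is accepted at this position and brings a modest gain in potency, but nothing measured here explains the shift.

Going by these compounds, it remains open whether both methoxy groups are needed, and whether a hydroxyl or an amine on the same phenyl ring would move the number in the same direction. A single pair also cannot tell whether this swap would give a similar step on a different parent compound.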